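From 4-fluorophenyl to a pyrrole side chain

A few compounds are considered here, and "the series" means these few. Any claim that something is new, unique, unknown or untested is made for them only; others in the source may bear on it.

In a functional assay on MCF7 cells (Homo sapiens) for antiproliferative activity, read by MTT assay, with a stated time of 72 h (on this read-out higher numbers stand for weaker inhibition and lower numbers for stronger inhibition), compound 1 `O=C(N/N=C/c1ccc(F)cc1)Nc1ccc(Oc2ccnc3[nH]ccc23)c(F)c1` gives 800 nM, while compound 2 `O=C(N/N=C/c1ccc(F)cc1)Nc1ccc(Oc2ccnc3[nH]ccc23)cc1` gives 3720 nM, the higher of the two numbers. Compound 3 `COc1ccc(/C=N/NC(=O)Nc2ccc(Oc3ccnc4[nH]ccc34)cc2)c(OC)c1OC` is reported as "not active" (no number reported). Compound 4 `CN(C)CCCn1cccc1/C=N/NC(=O)Nc1ccc(Oc2ccnc3[nH]ccc23)cc1` carries 1-(3-(dimethylamino)propyl)-1H-pyrrol-2-yl in place of 4-fluorophenyl on a carbon with a double bond to nitrogen. Within the data shown here, the only measured step, hydrogen in place of fluoro on an aromatic carbon, is modest: a 4.7-fold higher number from compound 1 to compound 2 (0.67 log units; beyond the scatter). It concerns a different place, so it offers only a rough size and no direction. In this assay the estimated step is a 1.1-fold lower number from compound 2 to compound 4 (0.03 log units; within the scatter), though one of that modest size either way would not surprise. Compound 4 is expected at 3500 nM, within an estimated range of 700 nM to 18000 nM.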

Compound 4, half-maximal inhibitory concentration: 9140 nM
Compound 4: the middle estimate sits 2.6-fold (0.42 log units) below what was measured; measured number inside the range.
By their numbers in this assay, from the lowest: compound 1; then compound 2; then compound 4.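

In this assay, among these compounds, the swap on a carbon with a double bond to nitrogen gives a 2.5-fold higher number from compound 2 to compound 4 (0.39 log units; beyond the scatter) and so puts a first number on a change at this place. The step is modest, and compound 4 still gives a number, whereas compound 3, with a different group at the same place, is reported as "not active". Nothing measured here explains the shift. Going by these compounds, whether the new ring or its 3-(dimethylamino)propyl chain sets the step stays open, since both changed together. A pyrrole carrying only a methyl on its nitrogen would separate the two.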